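Chloro in Place of Nitro: Expected Effect on HepG2 Potency

The source may hold more compounds than are shown below. What is called first, only, known or untested is meant among the compounds shown, and "the series" means these compounds.

Compound 1 `O=C(/C=C/c1cn(S(=O)(=O)c2ccc([N+](=O)[O-])cc2)c2ccccc12)c1ccncc1` stands lowest of the two numbers measured in a functional assay on HepG2 cells (Homo sapiens) for antiproliferative activity, read by MTT assay, with a stated time of 48 h (a higher number here means a weaker inhibitor, a lower number a stronger inhibitor), where compound 1 gives 18300 nM. Within the data shown here, its only measured neighbour is compound 2 `CCCS(=O)(=O)n1cc(/C=C/C(=O)c2ccncc2)c2ccccc21`, which gives 46200 nM; that step, a 2.5-fold higher number from compound 1 to compound 2 (0.40 log units; beyond the scatter), puts propyl in place of 4-nitrophenyl on the sulfonyl sulfur. Compound 3 `O=C(/C=C/c1cn(S(=O)(=O)c2ccc(Cl)cc2)c2ccccc12)c1ccncc1` differs from compound 1 at a single site: chloro in place of nitro on an aromatic carbon. Among the measured compounds shown here, no measured step alters just this group, so the propyl step bears only loosely on the question. Compound 3 is therefore expected to give 24000 nM (range 9000 nM to 65000 nM). The step of a 1.3-fold higher number from compound 1 to compound 3 (0.12 log units; within the scatter) is estimated to stay within the usual scatter.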

Compound 3, half-maximal inhibitory concentration: 35100 nM
Estimate against measurement, compound 3: 1.5-fold (0.17 log units) below; the measured number falls inside the stated range.
By their numbers in this assay, from the lowest: compounds 1, 3 and 2 (each within the scatter of the next, the first and the last beyond it).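

In this assay, chloro in place of nitro on this aromatic carbon gives a 1.9-fold higher number from compound 1 to compound 3 (0.28 log units; within the scatter) and so stays within the scatter. Setting 4-chlorophenyl in place of propyl on the sulfonyl sulfur gives a 1.3-fold lower number from compound 2 to compound 3 (0.12 log units; within the scatter) and also stays within it, so compound 3 lies within the scatter of both neighbours and does not show whether the gap between compound 1 and compound 2 comes from the aromatic ring or from its nitro group. No measurement available here accounts for these numbers. On these data alone, whether an amine or a methoxy group at this place would move the number beyond the scatter remains open, as does the effect of a longer chain on the sulfonyl sulfur.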